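Swapping the amide aryl group: from chlorophenyl to methoxyphenyl

The source may hold more compounds than are shown below. What is called first, only, known or untested is meant among the compounds shown, and "the series" means these compounds.

The series shares one core, shown by compound 3 (`Cc1occc1-c1nnc(SCC(=O)Nc2ccc(Cl)cc2)n1Cc1ccco1`), and was tested in a functional assay on CHO cells for antagonist activity at Orexin/Hypocretin receptor type 1 (Homo sapiens), read by FLIPR and calcium flux; a lower number here means a stronger inhibitor, a higher number a weaker inhibitor. Compound 3 gives 2000 nM and is the only one of the three with a numerical value. Compound 1 (`Cc1cccc(NC(=O)CSc2nnc(-c3ccoc3C)n2Cc2ccco2)c1C`) returns only a limit, > 15800 nM. Compound 2 (`Cc1ccc(NC(=O)CSc2nnc(-c3ccoc3C)n2Cc2ccco2)cc1`) likewise returns only a limit, > 15800 nM. The step that the two limits leave unreadable from compound 1 to compound 2 therefore cannot be read, while an at least 7.9-fold lower number from compound 1 to compound 3 (0.89 log units; beyond the scatter) and an at least 7.9-fold lower number from compound 2 to compound 3 (0.89 log units; beyond the scatter) both show that compound 3 is separated from the other two, with both of those sitting at the limit of > 15800 nM in this assay, at which 2 of the 3 values shown sit.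

Compound 4 (`COc1ccccc1NC(=O)CSc1nnc(-c2ccoc2C)n1Cc1ccco1`) carries 2-methoxyphenyl in place of 4-chlorophenyl on an amide-type nitrogen. The measured steps bear on this only indirectly: the chloro group that sets compound 3 apart is removed, and the two aryl groups that carried methyl groups instead gave only limits. Compound 4 is therefore expected to move back toward weaker inhibition, with an estimated step of a 5.0-fold higher number from compound 3 to compound 4 (0.70 log units; beyond the scatter) in this assay. Compound 4 is estimated at 10000 nM, within a range from 3000 nM to 30000 nM, and the chance that only a limit is reported is substantial.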

Compound 4, inhibition constant: > 15800 nM
Compound 4 gave a limit, no number; the forecaster's own chance of this, stated with the estimate: 45%; middle value at least 1.5-fold (0.19 log units) away from the limit.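

Replacing 4-chlorophenyl with 2-methoxyphenyl on the amide-type nitrogen in this assay gives an at least 7.9-fold higher number from compound 3 to compound 4 (0.89 log units; beyond the scatter), so this position now shows the same loss with an oxygen-bearing group as it did with the two methyl-bearing aryl groups. Adding a hydrogen-bond acceptor to this aryl group therefore does not by itself retain a measurable value, and among the four compounds only the 4-chlorophenyl group gives a number. The steps linking compound 4 to compound 1 and compound 2 cannot be read, so no order among these three can be stated, and the value of compound 4 is a limit, as are those of the other two: the limit of > 15800 nM in this assay, at which 3 of the 4 values shown sit.

The change from compound 3 to compound 4 alters both the substituent and its place on the phenyl ring, so the compounds shown cannot separate these two changes. On these data alone, it remains open how 4-methoxyphenyl or 2-chlorophenyl would compare in this assay, and whether 4-bromophenyl or 4-fluorophenyl would keep or improve on the value of compound 3.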